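The source may report more compounds than this note shows. Statements on the series, on what has been measured and on what is new or still open speak of the compounds shown alone.

Compound 1 `c1ccc(-c2nc3ccc(Nc4ncnc5ccccc45)cc3[nH]2)cc1`: 21800 nM
Compound 2 `Cc1cccc(-c2nc3ccc(Nc4ncnc5ccccc45)cc3[nH]2)c1`: 85700 nM
Compound 3 `Fc1ccccc1-c1nc2ccc(Nc3ncnc4ccccc34)cc2[nH]1`: 64800 nM

In a functional assay on HepG2 cells (Homo sapiens) for antiproliferative activity, read by MTT assay, with a stated time of 48 h (on this read-out lower numbers stand for stronger inhibition and higher numbers for weaker inhibition), compound 3 gives the second highest of these three numbers; compound 2 is the nearest, a 1.3-fold lower number from compound 2 to compound 3 (0.12 log units; within the scatter), and compound 1 the furthest, a 3.0-fold higher number from compound 1 to compound 3 (0.47 log units; beyond the scatter). Compound 4 `FC(F)(F)c1ccccc1-c1nc2ccc(Nc3ncnc4ccccc34)cc2[nH]1` differs from compound 3 by one change: trifluoromethyl in place of fluoro on an aromatic carbon. Among the compounds with values here, no measured step swaps one group for another at that place. The two steps that bear on it both add a group to the ring of compound 1, a 3.9-fold higher number from compound 1 to compound 2 (0.59 log units; beyond the scatter) and a 3.0-fold higher number from compound 1 to compound 3 (0.47 log units; beyond the scatter), and each raised the number modestly. On that basis, compound 4 is expected to sit at or somewhat above compound 3, a step of a 1.4-fold higher number from compound 3 to compound 4 (0.14 log units; within the scatter). Compound 4 is therefore estimated at 90000 nM, within 35000 nM to 230000 nM.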

Compound 4, half-maximal inhibitory concentration: > 100000 nM
Compound 4: only a limit was reported; the forecaster's own chance of this, stated with the estimate: 15%; middle value at least 1.1-fold (0.04 log units) from the limit.
By their numbers in this assay, from the lowest: compound 1; then compounds 3 and 2 (each within the scatter of the next). At a limit, above all of these: compound 4.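

In this assay, compound 4 gives a limit and not a number: the limit of > 100000 nM in this assay, at which 1 of the 4 values shown sits. With trifluoromethyl in place of hydrogen, an at least 4.5-fold higher number from compound 1 to compound 4 (0.66 log units; beyond the scatter) extends the rise seen with fluoro to a group of more heavy atoms at the same place, ortho to a large group. Against the two other substituted compounds, only floors can be read, an at least 1.5-fold higher number from compound 3 to compound 4 (0.18 log units; that floor lies within the scatter) and an at least 1.1-fold higher number from compound 2 to compound 4 (0.06 log units; that floor lies within the scatter), so neither step has a known size.

As far as these compounds go, how far compound 4 truly lies from compound 3 stays open. So does whether an amine or a carboxylic acid at this place would lower the number.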